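Ring Amine Substituent Swap: Amide to Propylsulfonyl

This account rests on a few compounds, and the source may have more. Where it says the series, first, only, none or still open, it means among the compounds named here.

The study centres on a shared core carried by three compounds. Compound 1 `CC(C)NC(=O)CN1CCN(c2ccc(OCC3CCN(C(=O)OC(C)C)CC3)cn2)CC1` in a functional assay on CHO-K1 cells for agonist activity at Glucose-dependent insulinotropic receptor (Homo sapiens), read by a luciferase reporter, with a stated time of 5 h (on this read-out lower numbers stand for an effect already at smaller amounts and higher numbers for an effect only at larger amounts of compound), reaches only the limit of the measurement, > 10000 nM. Among the compounds with values here, compound 2 `CC(C)OC(=O)N1CCC(COc2ccc(N3CCN(C(=O)c4ccco4)CC3)nc2)CC1` gives in this assay a value of 1900 nM, the only definite number among the two results. The other result, that of compound 1, is a limit (the limit of > 10000 nM in this assay, at which 1 of the 2 values shown sits). Within the data shown here, the single measured step, an at least 5.2-fold lower number from compound 1 to compound 2 (0.72 log units; beyond the scatter), shows that what sits on the amine nitrogen in the ring moves the read-out by a clearly meaningful amount.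

Compound 3 `CCCS(=O)(=O)N1CCN(c2ccc(OCC3CCN(C(=O)OC(C)C)CC3)cn2)CC1` is not yet measured. Against compound 2 its change is propylsulfonyl in place of (furan-2-yl)carbonyl on an amine nitrogen in a ring, on the same amine nitrogen in a ring that the measured step concerned. That step only shows that this position is sensitive; it gives no direction for a propylsulfonyl group. Compound 3 is therefore expected to land in a broad band around compound 2, estimated at 3000 nM with a range from 800 nM to 12000 nM, a step of a 1.6-fold higher number from compound 2 to compound 3 (0.20 log units; within the scatter) that is expected to stay near the scatter.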

Compound 3, half-maximal effective concentration: 300 nM
Beside the measured number, compound 3's estimate is 10-fold (1.00 log units) above it; the measured number lies below the stated range.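

In this assay, the earlier step showed only that the amine nitrogen in a ring is a sensitive position, whereas the new result gives a direction for one particular change: a 6.3-fold lower number from compound 2 to compound 3 (0.80 log units; beyond the scatter) shows that propylsulfonyl, which has no ring, gives a lower number here than (furan-2-yl)carbonyl with its five-membered aromatic ring. Among the compounds shown, the lowest number on this nitrogen therefore does not depend on an aromatic ring in the substituent, and the comparison with the (isopropylcarbamoyl)methyl group points the same way, with an at least 33-fold lower number from compound 1 to compound 3 (1.52 log units; beyond the scatter). That second step is a bound and not an exact size, as compound 1 stands at a limit of the assay: the limit of > 10000 nM in this assay, at which 1 of the 3 values shown sits.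

The compounds shown leave open whether the sulfonyl group or the propyl chain accounts for the lower number, a question that a butanoyl group on the same nitrogen would help to separate. They also leave open how far the number would move with a shorter methylsulfonyl group, a longer butylsulfonyl chain or a phenylsulfonyl group.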